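From an Aminohydroxyimidazole to a Hydantoin on the Ether Chain

The source may report more compounds than this note shows. Statements on the series, on what has been measured and on what is new or still open speak of the compounds shown alone.

Compound 3 `CCO/C(O)=C1\C(COCCn2c(N)cnc2O)=NC(C)=C(C(=O)OC)C1c1ccccc1Cl` gives the highest number of the three measured compounds, 158 nM in a functional assay (aorta) with Rattus norvegicus as the target; a lower number here means a stronger inhibitor, a higher number a weaker inhibitor. Compound 1 `CCO/C(O)=C1\C(COCCn2cc(N)n(C)c2=O)=NC(C)=C(C(=O)OC)C1c1ccccc1Cl` gives 25.1 nM in this assay, and compound 2 `CCO/C(O)=C1\C(COCCn2ccnc2C)=NC(C)=C(C(=O)OC)C1c1ccccc1Cl` gives 2.51 nM. Compound 4 `CCO/C(O)=C1\C(COCCN2C(=O)CNC2=O)=NC(C)=C(C(=O)OC)C1c1ccccc1Cl` has not been measured; it differs from compound 3 by 2,5-dioxoimidazolidin-1-yl in place of 5-amino-2-hydroxy-1H-imidazol-1-yl on a saturated chain carbon, two bonds along the chain from an oxygen on a saturated carbon. The measured steps that bear on this change are a 6.3-fold higher number from compound 1 to compound 3 (0.80 log units; beyond the scatter) and a 63-fold higher number from compound 2 to compound 3 (1.80 log units; beyond the scatter), both showing that the group at this place shifts the number well beyond the scatter. Since the entering group is neither of the two already measured, only a modest improvement is expected. For compound 4 the expected step is a 2.5-fold lower number from compound 3 to compound 4 (0.40 log units; beyond the scatter). Compound 4 is therefore estimated at 63 nM, with a range from 16 nM to 250 nM.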

Compound 4, half-maximal inhibitory concentration: 31.6 nM
Estimate against measurement, compound 4: 2.0-fold (0.30 log units) above; measured number inside the range.
By their numbers in this assay, from the lowest: compound 2; then compounds 1 and 4 (each within the scatter of the next); then compound 3.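

The change to 2,5-dioxoimidazolidin-1-yl, the only non-aromatic ring shown at this place, gives a 5.0-fold lower number from compound 3 to compound 4 (0.70 log units; beyond the scatter) in this assay. Set against the aromatic ring group of the other compound, it gives a 1.3-fold higher number from compound 1 to compound 4 (0.10 log units; within the scatter), so an aromatic ring is not needed to reach that level here. 2-Methyl-1H-imidazol-1-yl still keeps a clear lead, with a 13-fold higher number from compound 2 to compound 4 (1.10 log units; beyond the scatter).

Nothing measured here explains these shifts. Open, on these data alone, is how a plain amine or a carboxylic acid in place of the ring, or a longer chain carrying 2,5-dioxoimidazolidin-1-yl, would compare.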